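This account rests on a few compounds, and the source may have more. Where it says the series, first, only, none or still open, it means among the compounds named here.

Compound 1 `Cc1cc(C(=O)O)nn1-c1ccc(S(=O)(=O)N2CCC(=O)N(C3CCCCC3)C2=S)cc1` and compound 2 `CCCN1C(=O)CCN(S(=O)(=O)c2ccc(-n3nc(C)cc3C)cc2)C1=S` share the same core and differ in more than one place, so only their two values can be compared. In a functional assay on the whole organism (blood, strain albino) with Mus musculus as the target, with stated times of 6 days and 3 h, at a dose of 1 mmol/kg by the oral route (a lower number here means less inhibition, a higher number more inhibition at the dose given (going by the name of the read-out)), compound 1 gives 2%; compound 2 gives 1%. Compound 1 stands highest of the two numbers, yet its nearest, compound 2, lies within the scatter, so no order can be drawn between them; both read-outs are small. Compound 3 `C=CCN1C(=O)CCN(S(=O)(=O)c2ccc(-n3nc(C(=O)O)cc3C)cc2)C1=S` has not yet been measured in this assay. Compound 3 differs from compound 1 by allyl in place of cyclohexyl on an amide-type nitrogen in a ring. For the measured compounds named here, no step between measured compounds is available for this series, and no change on an amide-type nitrogen in a ring has yet been tested. Going by the values given here, the step of no change at the digits printed from compound 1 to compound 3 (within the scatter) is expected to be none beyond the scatter, since the series so far shows no read-out of any size. Compound 3 is expected to give 2% in this assay, within a range from -6% to 12%.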

Compound 3, a percentage reported as inhibition, in the whole organism at one dose (the size of the read-out at that dose, not a potency): 0%
Compound 3: the middle estimate sits 2 percentage points above what was measured; the range from low to high includes it.
By their numbers in this assay, from the lowest: compounds 3, 2 and 1 (each within the scatter of the next).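

In this assay, for the compounds shown here, the first step at this position reads a number 2 percentage points lower from compound 1 to compound 3 (within the scatter), for allyl in place of cyclohexyl on an amide-type nitrogen in a ring. Replacing a carbon-only six-membered ring with an open group of fewer heavy atoms and one double bond therefore leaves the read-out at this dose small, with no change beyond the scatter. Nothing available bears on a cause for this result.

With every read-out in the series this small, the step cannot show whether this position has any influence on the read-out at all. On these data alone, it remains open whether a longer chain, a benzyl group or a chain ending in an amine on this nitrogen would give a read-out clearly beyond the scatter.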